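The source may report more compounds than this note shows. Statements on the series, on what has been measured and on what is new or still open speak of the compounds shown alone.

Compound 1 `CC(C)=CC(O)C1=CC(=O)c2ccccc2C1=O` gives 5200 nM in a functional assay on WHCO1 cells (Homo sapiens) for cytotoxicity, read by MTT assay, with a stated time of 24 h; on this read-out lower numbers stand for stronger inhibition and higher numbers for weaker inhibition.
Compound 2 `O=C1C=C(C(O)c2ccccc2)C(=O)c2ccccc21` gives 3900 nM in this assay.
Compound 3 `O=C1C=C([C@H](O)c2ccccc2)C(=O)c2ccccc21` gives 4300 nM in this assay.

The three numbers sit close together: the step of a 1.3-fold lower number from compound 1 to compound 2 (0.12 log units; within the scatter) and the step of a 1.1-fold higher number from compound 2 to compound 3 (0.04 log units; within the scatter) both fall inside the usual scatter, so compound 2 cannot be told apart from compound 1 or compound 3. Compound 4 `O=C1C=C(C(O)c2ccc(F)cc2)C(=O)c2ccccc21` differs from compound 2 by fluoro in place of hydrogen on an aromatic carbon. Going by the values given here, no measured step touches the phenyl ring itself; the step from compound 1 to compound 2 replaced the whole group on the chain carbon and still stayed within the scatter, as did the step from compound 2 to compound 3. A small change on the ring is therefore expected to give no step beyond the scatter in this assay, an expected step of no change at the digits printed from compound 2 to compound 4 (within the scatter). Compound 4 is estimated at 3900 nM, within 1800 nM to 8500 nM.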

Compound 4, half-maximal inhibitory concentration: 5100 nM
Compound 4: the middle estimate sits 1.3-fold (0.12 log units) below what was measured, and the stated range covers the measured number.
By their numbers in this assay, from the lowest: compounds 2, 3, 4 and 1 (each within the scatter of the next).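

Fluoro on the aromatic carbon para to a large group gives a 1.3-fold higher number from compound 2 to compound 4 (0.12 log units; within the scatter) in this assay, so this one small change on the phenyl ring itself cannot be told apart from no change. Putting 4-fluorophenyl in place of 2-methylprop-1-en-1-yl gives a 1.0-fold lower number from compound 1 to compound 4 (0.01 log units; within the scatter) and also stays within the scatter. Nothing measured here bears on this result.

From the compounds shown here alone, whether an amine, a carboxylic acid or a methoxy group at this ring place would move the number beyond the scatter remains open. So does the effect of fluoro on the other ring carbons.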